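This account rests on a few compounds, and the source may have more. Where it says the series, first, only, none or still open, it means among the compounds named here.

Among the measured compounds shown here, compound 3 `COc1ccc(/C=C(\F)C(=O)c2cc(OC)c(OC)c(OC)c2)cc1F` gives 770 nM in an ADME assay on K562 cells (Homo sapiens) for cytotoxicity, read by MTT assay, with a stated time of 5 days (on this read-out higher numbers stand for weaker inhibition and lower numbers for stronger inhibition), which is the higher of the two numbers known here. Compound 2 `COc1ccc(/C=C(\F)C(=O)c2cc(OC)c(OC)c(OC)c2)cc1O` gives 13.7 nM. For the measured compounds named here, the only single-point change on record, a 56-fold higher number from compound 2 to compound 3 (1.75 log units; beyond the scatter), shows how much a fluoro in place of a hydroxy on the shared core raised the number. Compound 1 `COc1ccc(/C=C(\C#N)C(=O)c2cc(OC)c(OC)c(OC)c2)cc1Br` carries a nitrile in place of the vinyl fluorine and a bromo, and in this assay compound 1 sits at the limit of > 10000 nM (the limit of > 10000 nM in this assay, at which 1 of the 3 values shown sits). Compound 4 `COc1ccc(/C=C(\F)C(=O)c2cc(OC)c(OC)c(OC)c2)cc1Br` is reached by bromo in place of fluoro on an aromatic carbon. Going by the values given here, no measured step matches this halogen exchange, so the expectation rests on a modest shift: compound 4 is estimated at 1500 nM (range 300 nM to 8000 nM), a step of a 1.9-fold higher number from compound 3 to compound 4 (0.29 log units; within the scatter) that may or may not exceed the scatter.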

Compound 4, half-maximal inhibitory concentration: 6000 nM
Estimate against measurement, compound 4: 4.0-fold (0.60 log units) below; measured number inside the range.
By their numbers in this assay, from the lowest: compound 2; then compound 3; then compound 4. At a limit, above all of these: compound 1.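

On this aromatic carbon, ortho to a methoxy group, the two halogens do not behave alike: bromo in place of fluoro gives a 7.8-fold higher number from compound 3 to compound 4 (0.89 log units; beyond the scatter). Bromo in place of hydroxy gives a 440-fold higher number from compound 2 to compound 4 (2.64 log units; beyond the scatter), a larger step than the one for fluoro, so among these three groups hydroxy keeps the lowest number. On the chain, fluoro in place of cyano gives an at least 1.6-fold lower number from compound 1 to compound 4 (0.22 log units; that floor lies within the scatter), which leaves that change unsettled, and compound 1 rests on a limit: the limit of > 10000 nM in this assay, at which 1 of the 4 values shown sits. Going by these compounds, whether an amine or a carboxylic acid on this aromatic carbon would come close to hydroxy remains open.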